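A few compounds are considered here, and "the series" means these few. Any claim that something is new, unique, unknown or untested is made for them only; others in the source may bear on it.

Four compounds share a common core and differ in two places: the small group on a saturated ring carbon and the substituents on the aromatic ring joined through nitrogen. Compound 1, `CC1CC(=O)c2s/c(=N/c3ccccc3)oc2C1`, carries a methyl and an unsubstituted aromatic ring. In a functional assay on NCI-H23 cells (Homo sapiens) for antiproliferative activity, read by sulforhodamine B assay (on this read-out higher numbers stand for weaker inhibition of growth and lower numbers for stronger inhibition of growth), compound 1 gives 2720 nM. Compound 2, `CC(C)C1CC(=O)c2s/c(=N/c3ccccc3)oc2C1`, keeps the same aromatic ring but carries an isopropyl instead. In this assay compound 2 gives 2280 nM. The change between them, (isopropyl in place of methyl on a saturated ring carbon), produced a 1.2-fold lower number from compound 1 to compound 2 (0.08 log units; within the scatter), so the two values cannot be told apart by this measurement.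

Compound 3, `CC1CC(=O)c2s/c(=N/c3c(Cl)cc(Cl)cc3Cl)oc2C1`, carries the methyl of compound 1 together with three chlorine atoms on the aromatic ring. For compound 3 this assay reports only a limit, > 30000 nM, and no number. How the core of compound 3 differs from the core of compound 1 is not broken down here.

Compound 4, `CC(C)C1CC(=O)c2s/c(=N/c3c(Cl)cc(Cl)cc3Cl)oc2C1`, is not yet measured. It stands to compound 3 as compound 2 stands to compound 1, through the same change: isopropyl in place of methyl on a saturated ring carbon. Compound 4 is therefore expected to show a step that the limit leaves unreadable from compound 3 to compound 4, an expectation resting on the earlier step of a 1.2-fold lower number from compound 1 to compound 2 (0.08 log units; within the scatter) and on compound 3 sitting at the limit (the limit of > 30000 nM in this assay, at which 1 of the 3 values shown sits). Compound 4 is estimated at 40000 nM, with a likely range from 15000 nM to 120000 nM, most probably again reported only as a limit.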

Compound 4, concentration for 50% growth inhibition: > 30000 nM
Compound 4 ended at the assay's limit (the forecaster's own chance of this, stated with the estimate: 85%); the middle value does not contradict the limit.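

In this assay, compound 3 and compound 4 are both reported only as limits and not as numbers, so no step can be read between them: the limit of > 30000 nM in this assay, at which 2 of the 4 values shown sit.

The compounds shown leave open whether isopropyl in place of methyl on a saturated ring carbon changes growth inhibition at all when the aromatic ring carries the chlorine atoms of compound 3 and compound 4.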